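A few compounds are considered here, and "the series" means these few. Any claim that something is new, unique, unknown or untested is made for them only; others in the source may bear on it.

Compound 1 `CCC(C(=O)N1CCN(c2cccc(F)c2)CC1)N1C(=O)CCC1=O` gives 0% in a functional assay on the whole organism (strain Swiss) with Mus musculus as the target, in the maximal electroshock model, with a stated time of 2 h, at a dose of 300 mg/kg by the intraperitoneal route; a lower number here means a weaker effect, a higher number a stronger effect of the compound at the dose given.
Compound 2 `CCC(C(=O)N1CCN(c2ccc(F)cc2)CC1)N1C(=O)CCC1=O` gives 0% in this assay.
Compound 3 `CC(C(=O)N1CCN(c2ccc(F)cc2)CC1)N1C(=O)CCC1=O` gives 50% in this assay.

The three measured compounds share a core and differ in two places. Between compound 2 and compound 1 the difference is 3-fluorophenyl in place of 4-fluorophenyl on an amine nitrogen in a ring, and this change made no change at the digits printed from compound 2 to compound 1 (within the scatter). Between compound 2 and compound 3 the difference is hydrogen in place of methyl on a saturated chain carbon, two bonds along the chain from an amide-type nitrogen in a ring and a carbonyl carbon, and this change made a number 50 percentage points higher from compound 2 to compound 3 (beyond the scatter). Compound 3 thus stands highest of the three, and its steps to compound 1 and to compound 2 both lie beyond the scatter.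

Compound 4 `CC(C(=O)N1CCN(c2cccc(F)c2)CC1)N1C(=O)CCC1=O` has not yet been measured in this assay. It differs from compound 3 by 3-fluorophenyl in place of 4-fluorophenyl on an amine nitrogen in a ring, the same change that was made from compound 2 to compound 1, where it gave no change at the digits printed from compound 2 to compound 1 (within the scatter). The cores of compound 3 and compound 4 differ from those of compound 2 and compound 1 by hydrogen in place of methyl on a saturated chain carbon, two bonds along the chain from an amide-type nitrogen in a ring and a carbonyl carbon, so the change is now made on the core that carries the higher value.

On the measured pair the change left the read-out unmoved, and the only ground for an expectation is that one observation. Compound 4 is therefore expected to make a step of no change at the digits printed from compound 3 to compound 4 (within the scatter) from compound 3, resting on the step from compound 2 to compound 1 of no change at the digits printed from compound 2 to compound 1 (within the scatter). Compound 4 is estimated at 50%, with a range from 20% to 80%, the width reflecting that the change has been seen only once and on a different core.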

Compound 4, a percentage reported as activity, at one dose (the size of the read-out at that dose, not a potency): 100%
Estimate against measurement, compound 4: 50 percentage points below, outside the stated range (above it).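

In this assay, 3-fluorophenyl in place of 4-fluorophenyl on the amine nitrogen gave a number 50 percentage points higher from compound 3 to compound 4 (beyond the scatter), so the result of this change on one core did not carry over to the other: the same change on two cores in this assay, no change at the digits printed (within the scatter) from compound 2 to compound 1 and a number 50 percentage points higher (beyond the scatter) from compound 3 to compound 4, 50 percentage points apart, beyond the scatter of two such steps. Hydrogen in place of methyl on the saturated chain carbon, read with the 3-fluorophenyl group present, gave a number 100 percentage points higher from compound 1 to compound 4 (beyond the scatter), and the size of this change likewise differed with the group on the amine nitrogen: the same change on two cores in this assay, a number 50 percentage points higher (beyond the scatter) from compound 2 to compound 3 and a number 100 percentage points higher (beyond the scatter) from compound 1 to compound 4, 50 percentage points apart, beyond the scatter of two such steps. Together these steps show that, among these four compounds, the two changes do not act independently in this assay, but they do not show what underlies this dependence, and they rest on a single read-out at one dose, which is not a potency, with only one pair of cores compared.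

The compounds shown leave open whether other groups on the amine nitrogen, such as 3-chlorophenyl or 3-methoxyphenyl, would follow 3-fluorophenyl on the core of compound 4. They also leave open how a longer chain, such as propyl, on the saturated chain carbon would behave with either fluorophenyl group.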